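A few compounds are considered here, and "the series" means these few. Any claim that something is new, unique, unknown or untested is made for them only; others in the source may bear on it.

Among the measured compounds shown here, in a functional assay on cells for antagonist activity at Free fatty acid receptor 1 (Homo sapiens), read by TR-FRET and inositol phosphate accumulation, with a stated time of 2 h (a higher number here means a weaker inhibitor, a lower number a stronger inhibitor), compound 3 `CC1(C#N)CN(c2cc(COc3ccc(F)c(F)c3F)nc(-c3ccccn3)n2)C1` gives 158 nM, the lowest of the three numbers so far. In this assay compound 2 `Fc1ccc(OCc2cc(N3CC4(CCO4)C3)nc(-c3ccccn3)n2)c(F)c1F` gives 501 nM, and compound 1 `OC1CN(c2cc(COc3ccc(F)c(F)c3F)nc(-c3ccccn3)n2)C1` gives 3160 nM. All three share one core and differ only in the group on a single aromatic carbon, and each change there has moved the number beyond the scatter: a 6.3-fold lower number from compound 1 to compound 2 (0.80 log units; beyond the scatter), a 3.2-fold lower number from compound 2 to compound 3 (0.50 log units; beyond the scatter) and a 20-fold lower number from compound 1 to compound 3 (1.30 log units; beyond the scatter).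

Compound 4 `Fc1ccc(OCc2cc(OCC3CCC3)nc(-c3ccccn3)n2)c(F)c1F` has not yet been measured in this assay. It differs from compound 3 in one place: cyclobutylmethoxy in place of 3-cyano-3-methylazetidin-1-yl on an aromatic carbon. For the measured compounds named here, none of the measured pairs sets an ether-linked group against an azetidine on this carbon, so no step speaks directly to this change. What the three steps do show is that this position is sensitive, and that compound 3, the one bearing the nitrile, sits at the strong end of the spread. With the nitrile gone and the group now joined through oxygen, the expected outcome in this assay is a 5.1-fold higher number from compound 3 to compound 4 (0.70 log units; beyond the scatter), a weaker number, with wide uncertainty. Compound 4 is accordingly estimated at 800 nM, within a range from 200 nM to 4000 nM.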

Compound 4, half-maximal inhibitory concentration: 12.6 nM
Compound 4: the middle estimate sits 63-fold (1.80 log units) above what was measured; the whole stated range lies above it.
By their numbers in this assay, from the lowest: compound 4; then compound 3; then compound 2; then compound 1.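

In this assay, the three earlier compounds all carry a four-membered ring joined through its ring nitrogen, and they show only that this aromatic carbon is sensitive to what that ring bears. Cyclobutylmethoxy now leaves that series behind, with a 13-fold lower number from compound 3 to compound 4 (1.10 log units; beyond the scatter), a 40-fold lower number from compound 2 to compound 4 (1.60 log units; beyond the scatter) and a 250-fold lower number from compound 1 to compound 4 (2.40 log units; beyond the scatter), so compound 4 gives the lowest number of the four and every azetidine-bearing compound shown lies above it. A low number at this position therefore requires neither the nitrile nor a nitrogen link, and a group of carbon only apart from its linking oxygen, with a ring of carbon only, is tolerated here; nothing measured accounts for the size of these steps.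

This one change alters the link, the ring and the substituents together, so the compounds shown cannot separate their shares in the step. From the compounds shown here alone, how a cyclobutylmethylamino group, with nitrogen as the link, a cyclopentylmethoxy group or an open-chain butoxy group would read on this carbon remains open, and with it whether the oxygen link or the carbon-only ring matters more.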